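A few compounds are considered here, and "the series" means these few. Any claim that something is new, unique, unknown or untested is made for them only; others in the source may bear on it.

Compound 1 `O=C(Nc1ccc(Oc2ccnc3[nH]ccc23)c(F)c1)c1ccc(-c2ccccc2)cn1` gives 4390 nM in a functional assay on MCF7 cells (Homo sapiens) for cytotoxicity, read by MTT assay, with a stated time of 72 h; a higher number here means a weaker inhibitor, a lower number a stronger inhibitor. Compound 2 `Cc1ccc(-c2ccc(C(=O)Nc3ccc(Oc4ccnc5[nH]ccc45)c(F)c3)nc2)cc1` gives 8020 nM in this assay. Compound 3 `O=C(Nc1ccc(Oc2ccnc3[nH]ccc23)c(F)c1)c1ccc(-c2ccc(F)cc2)cn1` reaches only a limit, > 10000 nM, in this assay.

Compound 3 therefore stands at the weak end of the three measured values, at the limit of > 10000 nM in this assay, at which 1 of the 3 values shown sits, and its exact number is not known. Compound 4 `O=C(Nc1ccc(Oc2ccnc3[nH]ccc23)c(F)c1)c1ccc(-c2ccc(F)cc2F)cn1` differs from it in one place: fluoro in place of hydrogen on an aromatic carbon. Among the compounds with values here, the steps that bear on this change are an at least 2.2-fold higher number from compound 1 to compound 3 (0.35 log units; beyond the scatter) and an at least 1.2-fold higher number from compound 2 to compound 3 (0.09 log units; that floor lies within the scatter), while a 1.8-fold higher number from compound 1 to compound 2 (0.26 log units; within the scatter). A fluoro entering in place of hydrogen has so far given a weaker inhibitor, so for compound 4 a step that the limit leaves unreadable from compound 3 to compound 4 is expected, in the direction of a weaker inhibitor, most likely again returning only a limit. Compound 4 is estimated at 16000 nM, between 7000 nM and 40000 nM.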

Compound 4, half-maximal inhibitory concentration: > 10000 nM
Compound 4 ended at the assay's limit (the forecaster's own chance of this, stated with the estimate: 70%); the middle value lies beyond the limit too.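

In this assay, a second fluoro, ortho to a large group, does not bring compound 4 back inside the measurable range, and its value is a limit: the limit of > 10000 nM in this assay, at which 2 of the 4 values shown sit. Replacing phenyl with 2,4-difluorophenyl gives an at least 2.2-fold higher number from compound 1 to compound 4 (0.35 log units; beyond the scatter), while replacing 4-methylphenyl with it gives an at least 1.2-fold higher number from compound 2 to compound 4 (0.09 log units; that floor lies within the scatter).

As far as these compounds go, the step between the two limits cannot be read, so whether the second fluoro changes the value at all remains open. Also open, from the compounds shown here alone, is whether an amine or a carboxylic acid at this position would return a measurable value.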